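Swapping 2,6-dimethylbenzyl for cyclobutylmethyl in compound 3

The compounds below may be only part of what the source reports. "The series", "measured", "known", "first", "only" and "open" are said of these compounds alone.

- compound 1 `CC(=O)N1CC[C@H](C(=O)N2CC[C@](c3ccc(C(OCc4c(F)cccc4F)(C(F)(F)F)C(F)(F)F)cc3)(S(=O)(=O)c3ccc(F)cc3)C2)C1`: 19%
- compound 2 `O=C(N1CCOCC1)N1CC[C@](c2ccc(C(OCc3c(F)cccc3F)(C(F)(F)F)C(F)(F)F)cc2)(S(=O)(=O)c2ccc(F)cc2)C1`: 3%
- compound 3 `Cc1cccc(C)c1COC(c1ccc([C@]2(S(=O)(=O)c3ccc(F)cc3)CCN(C(=O)[C@H]3CC[C@H](C(=O)O)CC3)C2)cc1)(C(F)(F)F)C(F)(F)F`: 89%

These three numbers come from an ADME assay on microsomes from liver (Homo sapiens) for metabolic stability, with a stated time of 10 min; a lower number here means that less of the compound is left, a higher number that more of the compound is left. Compound 3, at 89%, stands highest of the three, well clear of the other two.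

The next compound is compound 4 `O=C(O)[C@H]1CC[C@H](C(=O)N2CC[C@](c3ccc(C(OCC4CCC4)(C(F)(F)F)C(F)(F)F)cc3)(S(=O)(=O)c3ccc(F)cc3)C2)CC1`, which keeps the carbonyl side of compound 3 and changes one other place: cyclobutyl in place of 2,6-dimethylphenyl on a saturated chain carbon bound to an oxygen on a saturated carbon. Put another way, 2,6-dimethylbenzyl gives way to cyclobutylmethyl.

Among the compounds with values here, only one measured step is available, a number 16 percentage points lower from compound 1 to compound 2 (beyond the scatter). That change sits on a carbonyl carbon, not at the place altered here, so it offers no direct guide. Within the data shown here, it shows only that a single change can move the number in this assay beyond the scatter. Among the measured compounds shown here, compound 1 and compound 2 also differ from compound 3 in more than one place, and no measured step covers this swap.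

Compound 3 already sits near the top of the scale at 89%, so there is more room to fall than to rise. The expected step, estimated with wide uncertainty, is a number 11 percentage points lower from compound 3 to compound 4 (beyond the scatter). The estimate for compound 4 is 78%, with an expected range from 52% to 97%.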

Compound 4, percent of the compound remaining: 85%
For compound 4 the middle estimate is 7 percentage points below the measured one; the range from low to high includes it.
By their numbers in this assay, from the lowest: compound 2; then compound 1; then compounds 4 and 3 (each within the scatter of the next).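

In this assay, putting cyclobutyl in place of 2,6-dimethylphenyl on a saturated chain carbon bound to an oxygen on a saturated carbon gives a number 4 percentage points lower from compound 3 to compound 4 (within the scatter) and so leaves the read-out within the usual spread of repeat measurements. Within the data shown here, this is the first direct reading at this position, and it shows that, with the rest of compound 3 kept, a group of eight carbon atoms with a six-membered aromatic ring can give way to one of four carbon atoms with a four-membered non-aromatic ring without a change that this assay can tell apart from scatter. No measured evidence shown here accounts for this result, so the pair records what happens at this position but not the reason for it.

On these data alone, compound 1 and compound 2 carry a different carbonyl side and a different group at this position, so it remains open whether the same swap would behave alike on either of those carbonyl sides. Also open, as far as these compounds go, is how this position would respond to a group such as an amine, a carboxylic acid or a longer chain in place of cyclobutyl.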